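A few compounds are considered here, and "the series" means these few. Any claim that something is new, unique, unknown or untested is made for them only; others in the source may bear on it.

Measured so far in a functional assay on MDA-MB-435 cells (Homo sapiens) for antiproliferative activity, read by sulforhodamine B assay, with a stated time of 48 h; on this read-out higher numbers stand for weaker inhibition of growth and lower numbers for stronger inhibition of growth:
Compound 1 `COc1ccc(OC)c(/C=C/c2nnc(Nc3ccc(Cl)cc3)o2)c1` gives > 100000 nM, a limit of the assay.
Compound 2 `COc1ccc(OC)c(/C=C/C(=O)N/N=C/c2ccc(Cl)cc2)c1` gives 98.8 nM.

Compound 2 holds the only number shown in this series; the other value stands at the limit recorded by the limit of > 100000 nM in this assay, at which 1 of the 2 values shown sits, for compound 1. Among the measured compounds shown here, no step between measured compounds is available, so the next compound is judged from its structure alone. Compound 3 `COc1ccc(OC)c(/C=C/C(=O)N/N=C/c2ccccc2)c1` carries hydrogen in place of chloro on an aromatic carbon, para to a large group, so that 4-chlorophenyl becomes phenyl while the shared core of compound 2 is kept. Compound 3 is expected to show a step of a 2.5-fold higher number from compound 2 to compound 3 (0.40 log units; beyond the scatter), a moderate move toward weaker inhibition of growth, close to the edge of the usual scatter. The estimate for compound 3 in this assay is 250 nM, with a range from 60 nM to 1500 nM.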

Compound 3, concentration for total growth inhibition: 1980 nM
Compound 3: middle estimate off by 7.9-fold (0.90 log units), on the low side, and the stated range ends below it.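

In this assay, among the compounds shown here, the change from 4-chlorophenyl to phenyl gives a 20-fold higher number from compound 2 to compound 3 (1.30 log units; beyond the scatter), the first step that can be read. The chloro on this aromatic carbon, para to a large group, is therefore not interchangeable with hydrogen on the shared core: its loss moves the read-out toward weaker inhibition of growth by a large step, well beyond the scatter. Nothing measured here gives a reason for the size of this step.

With a single pair, this result applies only to chloro and hydrogen on this core, and it sets no trend across substituents. Still open, as far as these compounds go, is whether fluoro, bromo, methoxy or trifluoromethyl at the same position would hold the number near that of compound 2 (98.8 nM) or move it toward that of compound 3.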